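The source may hold more compounds than are shown below. What is called first, only, known or untested is meant among the compounds shown, and "the series" means these compounds.

Compound 1 `Cc1ccc(C(=O)/C=C/c2cc(Br)ccc2O)cc1` and compound 2 `Cc1ccc(C(=O)CC2C(C#N)=C(N)Oc3ccc(Cl)cc32)cc1` were both tested in an ADME assay on MCF-10A cells (Homo sapiens) for cytotoxicity, read by sulforhodamine B assay, with a stated time of 72 h, tested at 30 uM; a higher number here means a stronger effect of the compound at the concentration tested, a lower number a weaker effect. Compound 1 gives 49.4% there, and in this assay compound 2 gives 53.3%, the higher of the two numbers on hand, though the gap to compound 1 lies within the usual scatter. Compound 3 `Cc1ccc(C(=O)CC2C(C#N)=C(N)Oc3ccc(Br)cc32)cc1` has not yet been tested. It differs from compound 2 by bromo in place of chloro on an aromatic carbon. Among the compounds with values here, no measured step of this kind exists among the compounds here, so the expected step of a number 0.3 percentage points lower from compound 2 to compound 3 (within the scatter) is small, with no change beyond the scatter in either direction. Compound 3 is therefore expected to give 53%, within 40% to 66%.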

Compound 3, a percentage reported as activity, at one concentration (the size of the read-out at that concentration, not a potency): 33.5%
The estimate for compound 3 lay 19.5 percentage points above the measured number, and the stated range ends above it.
By their numbers in this assay, from the lowest: compound 3; then compounds 1 and 2 (each within the scatter of the next).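

At this carbon, para to a fused ring, bromo in place of chloro gives a number 19.8 percentage points lower from compound 2 to compound 3 (beyond the scatter) in this assay. Exchanging one halogen atom for another, with no change in ring count, hydrogen-bond donors, hydrogen-bond acceptors or net charge, is therefore enough to shift this read-out, so the position is not indifferent to its substituent. Nothing available explains the step. Still open, going by these compounds, is how fluoro, a methoxy group or an amine at this carbon would read. One step also cannot show whether the same exchange would act alike on another core.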